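The compounds below may be only part of what the source reports. "The series", "measured", "known", "first", "only" and "open" are said of these compounds alone.

Measured in an ADME assay on SH-SY5Y cells (Homo sapiens) for cytotoxicity, read by MTT assay, with a stated time of 72 h; a lower number here means that less compound is tolerated, a higher number that more compound is tolerated:
Compound 1 `c1coc(-c2cn3ccccc3n2)c1`: > 100000 nM
Compound 2 `COc1ccc(-c2cn3cc(-c4ccco4)ccc3n2)cc1OC`: 30000 nM

Compound 1 gives > 100000 nM, which is a limit of this assay and not a number. Compound 3 `c1ccc(-c2ccc3nc(-c4ccco4)cn3c2)cc1` has phenyl in place of hydrogen on an aromatic carbon of the core of compound 1 (phenyl in place of hydrogen on an aromatic carbon). Compound 2, which also carries extra rings, gives 30000 nM. On that single value, a moderate fall is expected, meaning less compound tolerated, as the estimated at least 2.5-fold lower number from compound 1 to compound 3 (0.39 log units; beyond the scatter). For compound 3 the expected value is 40000 nM, with an estimated range from 15000 nM to 100000 nM.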

Compound 3, half-maximal cytotoxic concentration: 420 nM
The estimate for compound 3 lay 95-fold (1.98 log units) above the measured number, and the stated range ends above it.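

Phenyl in place of hydrogen on this aromatic carbon, two atoms from the ring nitrogen, brings in this assay an at least 230-fold lower number from compound 1 to compound 3 (2.37 log units; beyond the scatter), so a single added ring at this position can change the result greatly. Compound 1 gives > 100000 nM, which is a limit of the assay and not a number. The full size of the step therefore cannot be read: the limit of > 100000 nM in this assay, at which 1 of the 3 values shown sits.

From the compounds shown here alone, whether this change needs phenyl itself or would follow any group at this position stays open. A methyl, an amine or a carboxylic acid on the same carbon would help separate the two.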